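Third methoxy group on the amine-bearing ring: expected effect

The source may hold more compounds than are shown below. What is called first, only, known or untested is meant among the compounds shown, and "the series" means these compounds.

Compound 1 `COc1cccc(NCc2ccc(/C=C/C(=O)Nc3ccccc3N)cc2)c1` and compound 2 `COc1ccc(NCc2ccc(/C=C/C(=O)Nc3ccccc3N)cc2)cc1OC` share one core and differ in a single place. In a functional assay on HCT-116 cells (Homo sapiens) for antiproliferative activity, read by MTT assay (a higher number here means a weaker inhibitor, a lower number a stronger inhibitor), compound 1 gives 10000 nM and compound 2 gives 5000 nM. The step of a 2.0-fold lower number from compound 1 to compound 2 (0.30 log units; within the scatter) corresponds to a methoxy in place of hydrogen on an aromatic carbon. Among the compounds with values here, compound 2 thus holds the lowest of the two numbers so far, but its only comparator, compound 1, sits within the scatter of it, so no order between the two can be read from these values.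

Compound 3 `COc1cc(NCc2ccc(/C=C/C(=O)Nc3ccccc3N)cc2)cc(OC)c1OC` is not yet measured. It differs from compound 2 by methoxy in place of hydrogen on an aromatic carbon. Within the data shown here, the one measured step that bears on this change is a 2.0-fold lower number from compound 1 to compound 2 (0.30 log units; within the scatter), the same kind of substitution on the same ring, and it stayed within the scatter. On that basis a step of similar size, or none beyond the scatter, is expected in this assay, leaning lower if anywhere. Compound 3 is therefore estimated at 4000 nM, within 1500 nM to 12000 nM, which corresponds to an expected step of a 1.3-fold lower number from compound 2 to compound 3 (0.10 log units; within the scatter).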

Compound 3, half-maximal inhibitory concentration: 2000 nM
Compound 3: the middle estimate sits 2.0-fold (0.30 log units) above what was measured; the range from low to high includes it.
By their numbers in this assay, from the lowest: compound 3; then compounds 2 and 1 (each within the scatter of the next).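

In this assay, within the data shown here, a 2.5-fold lower number from compound 2 to compound 3 (0.40 log units; beyond the scatter) is the first step to lie beyond the scatter, though it is modest, so adding a methoxy in place of hydrogen on an aromatic carbon of this ring now has a readable effect on the number. The earlier step, a 2.0-fold lower number from compound 1 to compound 2 (0.30 log units; within the scatter), stayed within the scatter and could not show this; the new methoxy stands ortho to a methoxy group, meta to a second methoxy group and meta to a large group, and that is the placement at which a step beyond the scatter first appears. The data at hand offer no measurement that speaks to the origin of this step.

Still open, as far as these compounds go, is whether the step belongs to methoxy itself or would also follow from a hydroxy group, a fluorine atom or a longer ethoxy chain at the same place. Also open, from the compounds shown here alone, is whether a methoxy at this place would give a similar step without the other methoxy groups on the ring.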